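This account rests on a few compounds, and the source may have more. Where it says the series, first, only, none or still open, it means among the compounds named here.

Compound 2 `O=C(Nc1ccccc1)c1cc(Br)cc(Br)c1` stands at the edge of what an assay for inhibition of HSP60/HSP10 (Homo sapiens), with a stated time of 60 min (on this read-out lower numbers stand for stronger inhibition and higher numbers for weaker inhibition), can report: in this assay compound 2 gives only the limit > 100000 nM, not a number. Compound 1 `COc1c(Br)cc(Br)cc1C(=O)Nc1ccccc1` likewise returns only the limit > 100000 nM in this assay. The step from compound 1 to compound 2, a step that the two limits leave unreadable from compound 1 to compound 2, cannot be read because of the limit of > 100000 nM in this assay, at which 2 of the 2 values shown sit. Compound 3 `O=C(Nc1ccccc1)c1cc(Br)cc(Br)c1O` differs from compound 2 by hydroxy in place of hydrogen on an aromatic carbon. For the measured compounds named here, no measured step bears on this change; the single step known, hydrogen in place of methoxy, is unreadable. Compound 3 is therefore expected to stay close to the limit, the expected step of a number no higher from compound 2 to compound 3 (the limit leaves the size open) being unresolved. The estimate for compound 3 is 100000 nM, ranging from 30000 nM to 300000 nM.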

Compound 3, half-maximal inhibitory concentration: 63000 nM
Estimate against measurement, compound 3: 1.6-fold (0.20 log units) above; the measured number falls inside the stated range.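

In this assay, only the compound with hydroxy at this position, ortho to a bromo group and to the group of 9 heavy atoms, returns a number rather than a limit: an at least 1.5-fold lower number from compound 2 to compound 3 (0.20 log units; that floor lies within the scatter). Set against the methoxy of compound 1, the free hydroxy reads the same way: an at least 1.5-fold lower number from compound 1 to compound 3 (0.20 log units; that floor lies within the scatter). Both floors lie within the scatter, and the true size of each step stays unread because the other two compounds give only a limit: the limit of > 100000 nM in this assay, at which 2 of the 3 values shown sit.

On these data alone, whether an amine or a carboxylic acid at this position would also return a number stays open, as does the outcome for a longer chain on the oxygen.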